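This account rests on a few compounds, and the source may have more. Where it says the series, first, only, none or still open, it means among the compounds named here.

In a functional assay on MES-SA cells (Homo sapiens) for inhibition, with a stated time of 72 h, in the presence of a further agent that is not named here (on this read-out lower numbers stand for stronger inhibition and higher numbers for weaker inhibition), compound 1 `Oc1c(CN2CCCCC2)ccc2cccnc12` gives 4180 nM; 4070 nM (2 entries). Compound 2 `COCc1cc(CN2CCCC2)c(O)c2ncccc12` gives 10500 nM, the higher number of the two. This is its only numeric result, as a further entry holds no single number. Compound 3 `COCc1cc(CN2CCCCC2)c(O)c2ncccc12` has piperidin-1-yl in place of pyrrolidin-1-yl on a saturated chain carbon bound to an aromatic carbon. Compound 1, which also carries piperidin-1-yl, stands at 4180 nM; 4070 nM (2 entries), but it differs from compound 2 in more than one place, so it is only a weak guide. The expected step of a 1.4-fold lower number from compound 2 to compound 3 (0.15 log units; within the scatter) stays within the scatter, leaning toward stronger inhibition. For compound 3 the estimated value is 7500 nM, with an expected range of 3000 nM to 18000 nM.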

Compound 3, half-maximal inhibitory concentration: 9550 nM
Estimate against measurement, compound 3: 1.3-fold (0.10 log units) below; the measured number falls inside the stated range.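

Among the compounds shown here, on the shared core of compound 2, this is the first comparison that changes only the ring on a saturated chain carbon bound to an aromatic carbon, and it gives a 1.1-fold lower number from compound 2 to compound 3 (0.04 log units; within the scatter). In this assay, piperidin-1-yl and pyrrolidin-1-yl therefore cannot be told apart at this position. Repeat entries can agree closely in this read-out: the several entries of compound 1 in this assay, 4180 nM; 4070 nM (2 entries)

As far as these compounds go, whether this position responds to a larger change remains open, as both groups are saturated rings with one nitrogen; morpholin-4-yl or an open-chain diethylamino group would test this. From the compounds shown here alone, the effect of the other differences between compound 1 and compound 3 also remains open, as they differ in more than one place.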